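This account rests on a few compounds, and the source may have more. Where it says the series, first, only, none or still open, it means among the compounds named here.

In an ADME assay on S9 fraction from liver (Rattus norvegicus) for metabolic stability, read by LC-MS, using NADPH, with a stated time of 30 min (a lower number here means that less of the compound is left, a higher number that more of the compound is left), compound 1 `CCCCCCCCc1ccc(OCC(=O)Cn2nnc(C)n2)cc1` gives < 5%, which is a limit of the assay and not a number. Within the data shown here, compound 2 `CCCCCCCCc1ccc(OCC(=O)Cn2nnnc2C)cc1` gives 32%, and compound 3 `CCCCCCCCc1ccc(OCC(=O)Cn2nnnc2-c2ccncc2)cc1` gives 24%, within the scatter of compound 2, the only other number. Compound 4 `CCCCCCCCc1ccc(OCC(=O)Cn2nnnc2C(=O)OC)cc1` differs from compound 3 as follows: methoxycarbonyl in place of pyridin-4-yl on an aromatic carbon. Among the measured compounds shown here, the one measured change at this place, a number 8 percentage points lower from compound 2 to compound 3 (within the scatter), stayed within the scatter. The larger a number at least 27 percentage points higher from compound 1 to compound 2 (beyond the scatter) is a change of another kind and bears on this step less. No step beyond the scatter is therefore expected in this assay. The expected step is a number 6 percentage points lower from compound 3 to compound 4 (within the scatter). For compound 4 the estimate is 18%, with an expected range of 5% to 35%.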

Compound 4, percent of the compound remaining: 38%
Compound 4: middle estimate off by 20 percentage points, on the low side; measured number outside the range, above it.
By their numbers in this assay, from the lowest: compounds 3, 2 and 4 (each within the scatter of the next, the first and the last beyond it). At a limit, below all of these: compound 1.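

In this assay, the group at this position can now be seen to matter: methoxycarbonyl in place of pyridin-4-yl gives a number 14 percentage points higher from compound 3 to compound 4 (beyond the scatter). Methoxycarbonyl in place of methyl gives a number 6 percentage points higher from compound 2 to compound 4 (within the scatter), so these two groups are not separated here. Compound 1 stands at a limit of the assay and not at a number, so this step is only a bound: a number at least 33 percentage points higher from compound 1 to compound 4 (beyond the scatter).

As far as these compounds go, it remains open whether a carboxylic acid or an amide at this position would read like methoxycarbonyl or like pyridin-4-yl. From the compounds shown here alone, the effect of a shorter chain on the shared core also remains open.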